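The source may hold more compounds than are shown below. What is called first, only, known or untested is meant among the compounds shown, and "the series" means these compounds.

The measured compounds:
Compound 1, `Cc1ccc(-c2cc3nc(C)c(CN)c(-c4ccc(Cl)cc4Cl)n3n2)cc1`. In an assay on isolated protein for inhibition of Dipeptidyl peptidase 9 (Homo sapiens) (on this read-out lower numbers stand for stronger inhibition and higher numbers for weaker inhibition), compound 1 gives > 10000 nM, which is a limit of the assay and not a number.
Compound 2, `Cc1nc2nc(N3CCCC3)nn2c(-c2ccc(Cl)cc2Cl)c1CN`. In this assay compound 2 gives > 30000 nM, again a limit.
Compound 3, `Cc1nc2nc(C(=O)Nc3ccccc3)nn2c(-c2ccc(Cl)cc2Cl)c1CN`. In this assay compound 3 gives > 10000 nM, also a limit.

Among the measured compounds shown here, compound 1 therefore stands at the limit of > 10000 nM in this assay, at which 2 of the 3 values shown sit, and no compound in the set has a measured number; compound 2 stands at the limit of > 30000 nM in this assay, at which 1 of the 3 values shown sits. For the measured compounds named here, the only step between measured compounds, a step that the two limits leave unreadable from compound 2 to compound 3, lies between two limits and its size cannot be read. That step concerns a different change on a different core, so it says nothing about the change to compound 4, `Cc1cc2nc(C)c(CN)c(-c3ccc(Cl)cc3Cl)n2n1`, which is methyl in place of 4-methylphenyl on an aromatic carbon. Going by the values given here, no measured step bears on this place. With compound 1 at a limit, the step that the limit leaves unreadable from compound 1 to compound 4 is expected to leave compound 4 at or past the same limit. The estimate for compound 4 is 20000 nM, within 5000 nM to 100000 nM.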

Compound 4, inhibition constant: > 30000 nM
Compound 4 was reported as a limit; the forecaster's own chance of this, stated with the estimate: 85%; middle value at least 1.5-fold (0.17 log units) from the limit.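

Compound 1 and compound 4 are both reported only as limits, and the step between them, methyl in place of 4-methylphenyl, cannot be read. The compounds shown include no measured number, and they leave open whether any group at this place gives a measurable value.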